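Cyano in place of phenyl: an estimate

This account rests on a few compounds, and the source may have more. Where it says the series, first, only, none or still open, it means among the compounds named here.

compound 1 `CCCCNC(=O)NS(=O)(=O)c1ccc(OCC(CO[N+](=O)[O-])O[N+](=O)[O-])cc1`: 61000 nM
compound 2 `CCCCNC(=O)NS(=O)(=O)c1ccc(OCc2no[n+]([O-])c2-c2ccccc2)cc1`: > 100000 nM (a limit)

In a functional assay on thoracic aorta (strain Wistar) for inhibition, with Aorta (Rattus norvegicus) as the target, with a stated time of 120 min, in the presence of a further agent that is not named here (on this read-out lower numbers stand for an effect already at smaller amounts and higher numbers for an effect only at larger amounts of compound), compound 2 gives > 100000 nM, which is a limit of the assay and not a number. Compound 3 `CCCCNC(=O)NS(=O)(=O)c1ccc(OCc2no[n+]([O-])c2C#N)cc1` carries cyano in place of phenyl on an aromatic carbon. Going by the values given here, no two measured compounds differ in only one place, so no measured step shows how large this change may be. Compound 1, at 61000 nM, shows that a number can be read in this assay. A clear shift towards smaller amounts is expected, an estimated at least 33-fold lower number from compound 2 to compound 3 (1.52 log units; beyond the scatter). The estimate for compound 3 is 3000 nM, within an expected range of 300 nM to 30000 nM.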

Compound 3, half-maximal effective concentration: 900 nM
For compound 3 the middle estimate is 3.3-fold (0.52 log units) above the measured one, within the range that was stated.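

In this assay, this aromatic carbon of the five-membered ring proves highly sensitive to the group it carries: replacing phenyl with cyano gives an at least 110-fold lower number from compound 2 to compound 3 (2.04 log units; beyond the scatter) in a single change. Going by these compounds alone, this is the first direct view of what a change at this position can do. Going by these compounds, compound 2 stands at a limit and not at a number, so the true size of the step stays unknown: the limit of > 100000 nM in this assay, at which 1 of the 3 values shown sits.

On these data alone, whether a methyl, an amine or a carboxylic acid on this carbon would behave more like cyano or like phenyl stays open. A single step also cannot show whether the same change would work alike on another core.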